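The compounds below may be only part of what the source reports. "The series", "measured", "known", "first", "only" and "open" are said of these compounds alone.

Measured so far in a functional assay on HOP-62 cells (Homo sapiens) for inhibition, read by sulforhodamine B assay, with a stated time of 48 h, tested at 0.01 uM; on this read-out lower numbers stand for a stronger effect and higher numbers for a weaker effect at the one concentration tested:
compound 1 `COc1cc(Cl)cc(-c2nn(-c3cccc(NC(=O)Nc4ccc(Cl)c(C(F)(F)F)c4)c3)cc2-c2ccncc2)c1`: 100%
compound 2 `COc1cc(Cl)cc(-c2nn(-c3cccc(NC(=O)Nc4cc(C(F)(F)F)cc(C(F)(F)F)c4)c3)cc2-c2ccncc2)c1`: 93%
compound 3 `COc1cc(Cl)cc(-c2nn(-c3cccc(NC(=O)Nc4ccc(Cl)c(Cl)c4)c3)cc2-c2ccncc2)c1`: 92%

Compound 3 carries the lowest of the three numbers, but its gap to compound 2 and its gap to compound 1 both sit within the scatter, so the three compounds are not told apart by these readings. Next is compound 4 `COc1cc(Cl)cc(-c2nn(-c3cccc(NC(=O)Nc4cccc(C(F)(F)F)c4)c3)cc2-c2ccncc2)c1`, which differs from compound 3 in one place: 3-(trifluoromethyl)phenyl in place of 3,4-dichlorophenyl on an amide-type nitrogen. Within the data shown here, the only measured step that bears on this is a number 8 percentage points lower from compound 1 to compound 3 (within the scatter), which trades chloro and trifluoromethyl in the opposite sense and stays within the scatter. Compound 2, carrying two trifluoromethyl groups, also sits in the same band. Hence no step beyond the scatter is expected for compound 4: a number 4 percentage points higher from compound 3 to compound 4 (within the scatter). Compound 4 is accordingly estimated at 96%, between 85% and 103%.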

Compound 4, a percentage reported as activity, at one concentration (the size of the read-out at that concentration, not a potency): 96%
For compound 4 middle estimate and measured number coincide at the digits printed; measured number inside the range.
By their numbers in this assay, from the lowest: compounds 3, 2, 4 and 1 (each within the scatter of the next).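

In this assay, 3-(trifluoromethyl)phenyl in place of 3,4-dichlorophenyl on the amide-type nitrogen gives a number 4 percentage points higher from compound 3 to compound 4 (within the scatter) and is not told apart. Taking away one ring substituent is now read directly: hydrogen in place of trifluoromethyl gives a number 3 percentage points higher from compound 2 to compound 4 (within the scatter) and hydrogen in place of chloro gives a number 4 percentage points lower from compound 1 to compound 4 (within the scatter) so neither second substituent shows a readable contribution at this concentration. No supporting data explain these readings.

Going by these compounds, whether an amine or a carboxylic acid on this ring would give a step beyond the scatter stays open. On these data alone, how these compounds compare at higher concentrations also stays open.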